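The source may report more compounds than this note shows. Statements on the series, on what has been measured and on what is new or still open speak of the compounds shown alone.

Measured so far:
- Compound 1, `COc1cccc(N(C)c2ccc(NC(C)=O)cc2)c1`: 0.23 nM
- Compound 2, `COc1cccc(N(C)c2ccc(NC(=O)C(C)C)cc2)c1`: 5.5 nM

Both were tested in an assay on isolated protein for binding affinity to melatonin receptor type 1B (Homo sapiens); on this read-out higher numbers stand for weaker inhibition and lower numbers for stronger inhibition. On this read-out compound 2 has the highest number of the two measured compounds; its nearest neighbour is compound 1, and the step of a 24-fold higher number from compound 1 to compound 2 (1.38 log units; beyond the scatter) shows how far apart they lie. Compound 3, `CCOC(=O)Nc1ccc(N(C)c2cccc(OC)c2)cc1`, has not been measured yet. It differs from compound 2 in one place: ethoxy in place of isopropyl on a carbonyl carbon. Among the measured compounds shown here, the only measured step that bears on this position is a 24-fold higher number from compound 1 to compound 2 (1.38 log units; beyond the scatter), a large one, which shows that the group on this carbonyl carbon matters a great deal for this assay. Ethoxy matches isopropyl in the number of heavy atoms but brings a hydrogen-bond acceptor, so the outcome is uncertain. A moderate step downward, a 2.8-fold lower number from compound 2 to compound 3 (0.44 log units; beyond the scatter), is expected. Compound 3 is therefore estimated at 2 nM, with a range from 0.4 nM to 10 nM.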

Compound 3, inhibition constant: 7.2 nM
Beside the measured number, compound 3's estimate is 3.6-fold (0.56 log units) below it, within the range that was stated.
By their numbers in this assay, from the lowest: compound 1; then compounds 2 and 3 (each within the scatter of the next).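

Swapping isopropyl for ethoxy on the carbonyl carbon makes no real difference in this assay (a 1.3-fold higher number from compound 2 to compound 3 (0.12 log units; within the scatter)), so at this position the added hydrogen-bond acceptor of ethoxy brings no change beyond the scatter. Methyl remains apart from both larger groups: ethoxy gives a large step (a 31-fold higher number from compound 1 to compound 3 (1.50 log units; beyond the scatter)), much as isopropyl does (a 24-fold higher number from compound 1 to compound 2 (1.38 log units; beyond the scatter)), so the loss seen with isopropyl is not confined to that one group. Nothing available explains why these two groups read alike or why both differ from methyl.

From the compounds shown here alone, it remains open how a methoxy group would read on the same carbonyl carbon, which would show whether an oxygen at this place is compatible with the low number of compound 1. An amine or a longer chain such as propyl at this place also remains untested in the compounds shown.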